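Working notes: from compound 2 to compound 4

The source may report more compounds than this note shows. Statements on the series, on what has been measured and on what is new or still open speak of the compounds shown alone.

Measured so far in a functional assay on HeLa cells (Homo sapiens) for inhibition, read by CCK-8 assay, with a stated time of 48 h; on this read-out higher numbers stand for weaker inhibition and lower numbers for stronger inhibition:
compound 1 `COc1ccc(Oc2ccc(C(C)C)cc2-c2ccsc2S(=O)(=O)NCCNC(=O)Nc2cc(Cl)cc(Cl)c2)cc1OC` gives 11600 nM
compound 2 `O=C(NCCNS(=O)(=O)c1ccc(-c2ccccc2OCc2ccccc2)s1)Nc1cc(C(F)(F)F)cc(C(F)(F)F)c1` gives 13500 nM
compound 3 `O=C(NCCNS(=O)(=O)c1ccc(-c2ccccc2OCc2cccc(O)c2)s1)Nc1cc(Cl)cc(Cl)c1` gives > 50000 nM, which is a limit of this assay, not a number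

Compound 2 holds the highest of the two numbers shown; compound 1 sits within the scatter of it, so no order between the two can be stated. For compound 3 this assay reports only a limit, (the limit of > 50000 nM in this assay, at which 1 of the 3 values shown sits).

Compound 4 `O=C(NCCNS(=O)(=O)c1ccc(-c2ccccc2OCc2cccc(O)c2)s1)Nc1cc(C(F)(F)F)cc(C(F)(F)F)c1` differs from compound 2 in one place: hydroxy in place of hydrogen on an aromatic carbon. Among the compounds with values here, no measured pair carries this same change, so the step has no direct anchor. Compound 3, which carries the same (3-hydroxybenzyl)oxy group on the same core, reached the limit of this assay. The step of a 2.6-fold higher number from compound 2 to compound 4 (0.41 log units; beyond the scatter) is therefore expected to be a loss beyond the scatter. Compound 4 is estimated at 35000 nM, in the range 12000 nM to 90000 nM, with a fair chance that only a limit is reported.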

Compound 4, half-maximal inhibitory concentration: 17300 nM
Beside the measured number, compound 4's estimate is 2.0-fold (0.31 log units) above it; measured number inside the range.
By their numbers in this assay, from the lowest: compounds 1, 2 and 4 (each within the scatter of the next). At a limit, above all of these: compound 3.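

In this assay, going from benzyloxy to (3-hydroxybenzyl)oxy gives a 1.3-fold higher number from compound 2 to compound 4 (0.11 log units; within the scatter), so no change can be stated for this hydroxy on the aromatic carbon. The (3-hydroxybenzyl)oxy group therefore does not on its own bring a compound to the limit, since compound 4 still gives a number. Compound 3, which carries the same group, stands at a limit of the assay: the limit of > 50000 nM in this assay, at which 1 of the 4 values shown sits.

From the compounds shown here alone, whether an amine, a carboxylic acid or a methoxy at this place would shift the number stays open. Also open, going by these compounds, is what this hydroxy does alongside the two chlorines of compound 3, where no step can be read.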